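The compounds below may be only part of what the source reports. "The series", "measured", "known", "first", "only" and "open" are said of these compounds alone.

Compound 1 `COc1ccc(/C=C\c2cc(OC)c(OC)c(OC)c2)cc1OCc1ccc(CN2CC(C(=O)O)C2)cc1` in an ADME assay on HEK293 cells (Homo sapiens) for cytotoxicity, read by CCK-8 assay, with a stated time of 48 h (a higher number here means a weaker inhibitor, a lower number a stronger inhibitor), gives only a limit, > 50000 nM. Compound 2 `COc1ccc(/C=C\c2cc(OC)c(OC)c(OC)c2)cc1OCc1ccc(CN2C[C@H](O)C[C@@H]2C(=O)O)cc1` in this assay likewise gives a limit, > 50000 nM. Compound 3 `COc1ccc(/C=C\c2cc(OC)c(OC)c(OC)c2)cc1OCc1ccc(CN2CC[C@H](O)C2)cc1` in this assay also gives a limit, > 50000 nM.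

Compound 2 therefore stands where every shown value sits, at the limit of > 50000 nM in this assay, at which 3 of the 3 values shown sit. The steps a step that the two limits leave unreadable from compound 1 to compound 2 and a step that the two limits leave unreadable from compound 2 to compound 3 are both unreadable for that reason, and so is a step that the two limits leave unreadable from compound 1 to compound 3. Compound 4 `COc1ccc(/C=C\c2cc(OC)c(OC)c(OC)c2)cc1OCc1ccc(CN2CCCCC2C(=O)NCCN)cc1` differs from compound 2 by 2-((2-aminoethyl)carbamoyl)piperidin-1-yl in place of 2-carboxy-4-hydroxypyrrolidin-1-yl on a saturated chain carbon bound to an aromatic carbon. No measured step bears readably on this change, so no direction or size beyond the scatter can be drawn from the shown steps. Compound 4 is accordingly expected to sit near the same limit, with a number no higher from compound 2 to compound 4 (the limit leaves the size open) estimated, giving an expected 50000 nM between 20000 nM and 120000 nM.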

Compound 4, half-maximal inhibitory concentration: > 50000 nM
Compound 4 gave a limit, no number (the forecaster's own chance of this, stated with the estimate: 70%); the middle value sits exactly at the limit.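

The steps linking compound 4 with compound 1, compound 2 and compound 3 cannot be read, as each gives only a limit: the limit of > 50000 nM in this assay, at which 4 of the 4 values shown sit. On these data alone, whether any of these groups changes the true value in this assay stays open.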